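Core series at the limit: piperazine replaced by bridged diamine

The source may report more compounds than this note shows. Statements on the series, on what has been measured and on what is new or still open speak of the compounds shown alone.

In a functional assay on CCRF-CEM cells for agonist activity at C-X-C chemokine receptor type 4 (Homo sapiens), read by calcium flux, with a stated time of 25 min (a lower number here means that less compound is needed, a higher number that more compound is needed for the effect), compound 3 `CN1CCN(c2cccc3c2C[C@H](CN(C)[C@H]2CCCc4cccnc42)NC3)CC1` gives only a limit, > 30000 nM. Compound 1 `CC(C)N1CCN(c2cccc3c2C[C@H](CN(C)[C@H]2CCCc4cccnc42)NC3)CC1` likewise stops at a limit, > 30000 nM. Compound 2 `CN(C[C@H]1Cc2c(cccc2N2CCN3CCC[C@@H]3C2)CN1)[C@H]1CCCc2cccnc21` also reaches only a limit, > 30000 nM. The steps a step that the two limits leave unreadable from compound 1 to compound 2, a step that the two limits leave unreadable from compound 1 to compound 3 and a step that the two limits leave unreadable from compound 2 to compound 3 thus carry no readable size; what unites the set is the limit of > 30000 nM in this assay, at which 3 of the 3 values shown sit. Compound 4 `CN(C[C@H]1Cc2c(cccc2N2C[C@@H]3C[C@H]2CN3)CN1)[C@H]1CCCc2cccnc21` carries a group of 7 heavy atoms (5 carbon, 2 nitrogen; 2 five-membered non-aromatic rings with 1 hetero atom each) in place of a group of 7 heavy atoms (5 carbon, 2 nitrogen; one six-membered non-aromatic ring with 2 hetero atoms), on an aromatic carbon. Among the compounds with values here, none of the measured steps gives a readable effect of the group on this aromatic carbon, as all three values are limits. The step from compound 3 to compound 4 is therefore expected to show a number no higher from compound 3 to compound 4 (the limit leaves the size open), most likely again ending at a limit in this assay. Compound 4 is estimated at 30000 nM, with a range from 10000 nM to 100000 nM.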

Compound 4, half-maximal effective concentration: > 30000 nM
Compound 4 gave a limit, no number; the forecaster's own chance of this, stated with the estimate: 85%; the middle value sits exactly at the limit.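

No step among compound 1, compound 2, compound 3 and compound 4 can be read, and all four stop at the same limit: the limit of > 30000 nM in this assay, at which 4 of the 4 values shown sit.

The compounds shown leave open what size any of these group changes has in this assay and which group on this aromatic carbon would give a number.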